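Triazole-linked ethers: the step from compound 2 to compound 3

The source may hold more compounds than are shown below. What is called first, only, known or untested is meant among the compounds shown, and "the series" means these compounds.

Measured so far in a functional assay on SW480 cells (Homo sapiens) for cytotoxicity, read by MTT assay, with a stated time of 48 h; a lower number here means a stronger inhibitor, a higher number a weaker inhibitor:
- compound 1 `O=c1ccoc2cc(OCc3cn(Cc4cccc(F)c4)nn3)ccc12` — > 100000 nM
- compound 2 `O=c1ccoc2cc(OCc3cn(Cc4cccc([N+](=O)[O-])c4)nn3)ccc12` — > 100000 nM

Both values are limits of this assay, not numbers. Compound 1 sits at the limit > 100000 nM. Compound 2 likewise sits at the limit > 100000 nM. For the measured compounds named here, the step that the two limits leave unreadable from compound 1 to compound 2 is therefore unreadable; the only evidence is the limit of > 100000 nM in this assay, at which 2 of the 2 values shown sit.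

Compound 3 `N#Cc1ccc(Cn2cc(COc3ccc4c(=O)ccoc4c3)nn2)cc1` differs from compound 2 by 4-cyanophenyl in place of 3-nitrophenyl on a saturated chain carbon bound to an aromatic nitrogen. Going by the values given here, no measured step reads out a size for this change, since both measured compounds stand at the limit. The expected step that the limit leaves unreadable from compound 2 to compound 3 is accordingly none beyond the scatter, with compound 3 most likely again reported as a limit. Compound 3 is estimated at 150000 nM, range 40000 nM to 600000 nM.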

Compound 3, half-maximal inhibitory concentration: > 100000 nM
Compound 3 ended at the assay's limit; the forecaster's own chance of this, stated with the estimate: 85%; the middle value is on the limit's open side.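

No new step can be read among compound 1, compound 2 and compound 3, since each is reported only as a limit: the limit of > 100000 nM in this assay, at which 3 of the 3 values shown sit.

The compounds shown leave open how these three rank against one another and which change would give a readable value.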